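Acetyl in place of methylcyclopropanecarbonyl on the shared core

The source may hold more compounds than are shown below. What is called first, only, known or untested is meant among the compounds shown, and "the series" means these compounds.

Two amides of the shared core have been measured. In an assay on SHEP1 cells for displacement of a labelled ligand from Neuronal acetylcholine receptor; alpha4/beta2 (Homo sapiens), read by scintillation counting, with a stated time of 2 h (on this read-out lower numbers stand for stronger inhibition and higher numbers for weaker inhibition), compound 1 `C[C@@H]1C[C@H]1C(=O)N1CC2CNCC2C1` gives 4 nM, and compound 2 `C[C@H]1C[C@@H]1C(=O)N1CC2CNCC2C1` gives 43 nM. The step of an 11-fold higher number from compound 1 to compound 2 (1.03 log units; beyond the scatter) rests on (the fact that one of compounds 1 and 2 is drawn with a defined configuration and the other without, at the place where they differ). Compound 2 therefore stands at the higher of the two numbers in this assay.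

Compound 3 `CC(=O)N1CC2CNCC2C1` differs from compound 2 by methyl in place of 2-methylcyclopropyl on a carbonyl carbon. Among the compounds with values here, the single measured step concerns only the drawn configuration of the ring carbons and does not touch the acyl group, so no measured step bears directly on this change. Going by these compounds, its size and direction in this assay therefore remain open. On the numbers available, compound 3 is expected to give 80 nM, with a range from 15 nM to 400 nM. This estimate means a step of a 1.9-fold higher number from compound 2 to compound 3 (0.27 log units; within the scatter), expected to lie near the scatter.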

Compound 3, inhibition constant: 38 nM
The estimate for compound 3 lay 2.1-fold (0.32 log units) above the measured number; the range from low to high includes it.
By their numbers in this assay, from the lowest: compound 1; then compounds 3 and 2 (each within the scatter of the next).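

In this assay, methyl in place of 2-methylcyclopropyl on a carbonyl carbon gives a 1.1-fold lower number from compound 2 to compound 3 (0.05 log units; within the scatter), whereas the same replacement gives a 9.5-fold higher number from compound 1 to compound 3 (0.98 log units; beyond the scatter). The outcome of this change therefore depends on which drawn form of the 2-methylcyclopropyl group leaves: losing the ring and its defined stereocentres matters when starting from compound 1, but not, within the scatter, when starting from compound 2. Nothing in the evidence at hand explains this difference between the two starting points.

Going by these compounds, it remains open whether an unsubstituted cyclopropyl or an ethyl on the carbonyl carbon would match compound 1 or stay with compound 3. The effect of a longer chain or an amine at the same place is equally unknown.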